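Swapping the aryl group on the ring nitrogen: a forecast

The compounds below may be only part of what the source reports. "The series", "measured", "known", "first", "only" and "open" are said of these compounds alone.

Compound 2 `CC(C)OC(=O)N1CCC(Oc2ncnc3c2CCN3c2ccc(C#N)cc2F)CC1` gives 63.1 nM in a functional assay on CHO-K1 cells for agonist activity at Glucose-dependent insulinotropic receptor (Homo sapiens), read by a luciferase reporter, with a stated time of 5 h; a lower number here means that less compound is needed, a higher number that more compound is needed for the effect; its only companion, compound 1 `CC(C)OC(=O)N1CCC(Oc2ncnc3c2CCN3c2ccc(S(C)(=O)=O)cc2F)CC1`, gives 50.1 nM, and the shift a 1.3-fold higher number from compound 1 to compound 2 (0.10 log units; within the scatter) separates the two. Compound 3 `CC(C)OC(=O)N1CCC(Oc2ncnc3c2CCN3c2ccc(S(C)(=O)=O)cn2)CC1` differs from compound 2 by 5-(methylsulfonyl)pyridin-2-yl in place of 4-cyano-2-fluorophenyl on a nitrogen on an aromatic ring in a ring. Among the compounds with values here, only one measured step bears on this: the exchange between methylsulfonyl and cyano moved the number by a 1.3-fold higher number from compound 1 to compound 2 (0.10 log units; within the scatter). Nothing measured speaks to the change of ring. Compound 3 is therefore expected to stay close to both, with a step of a 1.1-fold lower number from compound 2 to compound 3 (0.02 log units; within the scatter), giving an estimate of 60 nM with a range from 20 nM to 200 nM.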

Compound 3, half-maximal effective concentration: 126 nM
For compound 3 the middle estimate is 2.1-fold (0.32 log units) below the measured one, and the stated range covers the measured number.
By their numbers in this assay, from the lowest: compounds 1, 2 and 3 (each within the scatter of the next, the first and the last beyond it).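

In this assay, the group on this ring nitrogen now proves sensitive to the aromatic ring itself: with methylsulfonyl present on both sides, 5-(methylsulfonyl)pyridin-2-yl in place of 2-fluoro-4-(methylsulfonyl)phenyl gives a modest step beyond the scatter (a 2.5-fold higher number from compound 1 to compound 3 (0.40 log units; beyond the scatter)). Replacing 4-cyano-2-fluorophenyl changes two features at once and stays within the scatter (a 2.0-fold higher number from compound 2 to compound 3 (0.30 log units; within the scatter)). Nothing measured here explains the step.

As far as these compounds go, it remains open how an amine or a carboxylic acid would fare in place of methylsulfonyl on this ring.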